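Naphthalen-2-yl in place of 4-nitrophenyl on a second core

A few compounds are considered here, and "the series" means these few. Any claim that something is new, unique, unknown or untested is made for them only; others in the source may bear on it.

Four compounds are in view. Compound 1 `C=C(CC)C(=O)c1ccc(OCc2nc(-c3ccc([N+](=O)[O-])cc3)cs2)c(C)c1C` and compound 2 `C=C(CC)C(=O)c1ccc(OCc2nc(-c3ccc4ccccc4c3)cs2)c(C)c1C` share one core, while compound 3 `C=C(CC)C(=O)c1ccc(OCc2nc(-c3ccc([N+](=O)[O-])cc3)cs2)cc1Cl` and the still unmeasured compound 4 `C=C(CC)C(=O)c1ccc(OCc2nc(-c3ccc4ccccc4c3)cs2)cc1Cl` share another; the difference between the two cores is not broken down here. In a functional assay on HL-60 cells (Homo sapiens) for inhibition, read by trypan blue exclusion, with a stated time of 72 h (a higher number here means a weaker inhibitor of growth, a lower number a stronger inhibitor of growth), compound 1 gives 3600 nM, compound 2 gives 2000 nM, and compound 3 gives 800 nM. Compound 3 thus has the lowest number of the three, and its gaps to compound 2 and to compound 1 both lie beyond the scatter.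

Between compound 1 and compound 2 the change is naphthalen-2-yl in place of 4-nitrophenyl on an aromatic carbon, and it made a 1.8-fold lower number from compound 1 to compound 2 (0.26 log units; within the scatter). The same change, (naphthalen-2-yl in place of 4-nitrophenyl on an aromatic carbon), now links compound 3 to compound 4, with the place line the same word for word, so it is the same change carried onto the second core.

For compound 4 the account expects a 1.8-fold lower number from compound 3 to compound 4 (0.25 log units; within the scatter) in this assay, an expectation that rests on a 1.8-fold lower number from compound 1 to compound 2 (0.26 log units; within the scatter), a step that stayed within the scatter. Because a 1.8-fold lower number from compound 1 to compound 2 (0.26 log units; within the scatter) was small, the forecast for compound 4 sits close to compound 3. Compound 4 is therefore estimated at 450 nM in this assay, with a likely span from 200 nM to 1200 nM, pending the measurement.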

Compound 4, concentration for 50% growth inhibition: 900 nM
Compound 4: the middle estimate sits 2.0-fold (0.30 log units) below what was measured; the range from low to high includes it.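

In this assay, naphthalen-2-yl in place of 4-nitrophenyl on the second core made a 1.1-fold higher number from compound 3 to compound 4 (0.05 log units; within the scatter) and so stayed within the scatter, as it did on the first core. Set side by side, the two steps do not differ by more than such steps can be expected to scatter: the same change on two cores in this assay, a 1.8-fold lower number (0.26 log units; within the scatter) from compound 1 to compound 2 and a 1.1-fold higher number (0.05 log units; within the scatter) from compound 3 to compound 4, 2.0-fold (0.31 log units) apart, within the scatter of two such steps. This shows that, in these two pairs, the change carried from one core to the other as a small step, but it does not show that the change has the same size or direction on both cores, and two pairs do not establish a rule for other cores in the series.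

On these data alone, it remains open whether a phenyl ring bearing an amine or a carboxylic acid at this place, on the aromatic carbon next to the ring nitrogen, would also give so small a step on either core. Also open is which part of the difference between the two cores matters in this assay, as the two pairs shown vary only the group at this place and leave that difference unresolved.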